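This account rests on a few compounds, and the source may have more. Where it says the series, first, only, none or still open, it means among the compounds named here.

In an ADME assay on PA-1 cells (Homo sapiens) for cytotoxicity, read by MTT assay, with a stated time of 72 h (a lower number here means a stronger inhibitor, a higher number a weaker inhibitor), compound 1 (`COc1cc(C2=C(c3cc(C)c(OC)c(C)c3)C(OC(C)=O)CC2=O)cc(OC)c1OC`) gives > 100 ug/mL, which is a limit and not a number. Compound 2 (`COc1ccc(C2=C(c3cc(OC)c(OC)c(OC)c3)C(=O)C(OC(C)=O)C2)cc1Cl`) gives > 100 ug/mL, also a limit. Compound 1 therefore stands with compound 2 at the limit of > 100 ug/mL in this assay, at which 2 of the 3 values shown sit. Compound 3 (`COc1ccc(C2=C(c3cc(OC)c(OC)c(OC)c3)C(=O)CC2OC(C)=O)cc1NC=O`) gives 5 ug/mL.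

For the measured compounds named here, the one measured step is an at least 20-fold lower number from compound 1 to compound 3 (1.30 log units; beyond the scatter). That step acts on a double-bonded ring carbon, so it gives no direct size for a change on the oxygen.

Compound 4 (`COc1cc(C2=C(c3cc(C)c(OC)c(C)c3)C(O[SiH2]C(C)(C)C)CC2=O)cc(OC)c1OC`) keeps the core of compound 1 and differs by a group of 5 heavy atoms (4 carbon, 1 silicon; no ring) in place of a group of 3 heavy atoms (2 carbon, 1 oxygen; no ring), on an oxygen on a saturated carbon. The acetyl leaves, and a group of 5 heavy atoms (4 carbon, 1 silicon; no ring) enters on an oxygen on a saturated carbon. Going by the values given here, no measured step covers this oxygen, so the expectation rests on compound 1 and its limit of > 100 ug/mL.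

No step beyond the scatter is expected in this assay, although a lower number cannot be ruled out. The estimated step is a number no higher from compound 1 to compound 4 (the limit leaves the size open). For compound 4 the expected value is 100 ug/mL, within an estimated range of 30 ug/mL to 200 ug/mL.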

Compound 4, half-maximal inhibitory concentration: 32 ug/mL
The estimate for compound 4 lay 3.1-fold (0.49 log units) above the measured number; low and high end bracket the measured number.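

In this assay, for the compounds shown here, the only earlier step acted on a double-bonded ring carbon; an at least 3.1-fold lower number from compound 1 to compound 4 (0.49 log units; beyond the scatter) now shows that the group on the oxygen on a saturated carbon also changes the read-out on the core of compound 1. The acetyl is therefore not needed for a measurable value on this core. Compound 1 has a limit and not a number, so the step has only a lower bound: the limit of > 100 ug/mL in this assay, at which 2 of the 4 values shown sit.

As far as these compounds go, whether the silicon or the carbon atoms of the entering group carry the step stays open, as does what a butanoyl chain or a bare hydroxyl would give at this oxygen. Also open, from the compounds shown here alone, is whether the same exchange would lower the number for compound 3, which carries a 3-(formylamino)-4-methoxyphenyl group.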